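Pyridin-4-yl for pyridin-3-yl on two different cores

A few compounds are considered here, and "the series" means these few. Any claim that something is new, unique, unknown or untested is made for them only; others in the source may bear on it.

Measured compounds in a functional assay on SMMC-7721 cells (Homo sapiens) for cytotoxicity, read by MTT assay, with a stated time of 24 h; a lower number here means a stronger inhibitor, a higher number a weaker inhibitor:

Compound 1, `CN1C/C(=C\c2cccnc2)C(=O)/C(=C/c2ccccc2C(F)(F)F)C1`, gives 3900 nM.
Compound 2, `CN1C/C(=C\c2ccncc2)C(=O)/C(=C/c2ccccc2C(F)(F)F)C1`, gives 4100 nM.
Compound 3, `O=C1/C(=C/c2cccnc2)CNC/C1=C\c1ccccc1F`, gives > 20000 nM, which is a limit of the assay and not a number.

Compound 1 and compound 2 share a core and differ by pyridin-4-yl in place of pyridin-3-yl on a double-bonded chain carbon bound to a double-bonded ring carbon. The step is a 1.1-fold higher number from compound 1 to compound 2 (0.02 log units; within the scatter), so in this assay the two values show no difference that can be read as a change.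

Compound 3 carries a different core; the difference between its core and the core of compound 1 is not broken down here. Compound 3 sits at the limit of > 20000 nM in this assay, at which 1 of the 3 values shown sits, so for it only a limit is known.

Compound 4, `O=C1/C(=C/c2ccncc2)CNC/C1=C\c1ccccc1F`, is not yet measured. It differs from compound 3 by pyridin-4-yl in place of pyridin-3-yl on a double-bonded chain carbon bound to a double-bonded ring carbon, the same kind of change as from compound 1 to compound 2, at a place described in the same words. Given that the earlier step was within the scatter, the step from compound 3 to compound 4 is expected to be small as well, a step that the limit leaves unreadable from compound 3 to compound 4. Since compound 3 gave only a limit, compound 4 is expected to give 25000 nM in this assay, most likely again as a limit, with a range from 12000 nM to 60000 nM.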

Compound 4, half-maximal inhibitory concentration: 18400 nM
The estimate for compound 4 lay 1.4-fold (0.13 log units) above the measured number; the range from low to high includes it.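

In this assay, pyridin-4-yl in place of pyridin-3-yl on a double-bonded chain carbon bound to a double-bonded ring carbon gives an at least 1.0-fold lower number from compound 3 to compound 4 (0.03 log units; that floor lies within the scatter), and this figure is a floor for the step on the core of compound 3, not its measured size. Compound 3 is known only by a limit of the assay: the limit of > 20000 nM in this assay, at which 1 of the 4 values shown sits.

Set beside the step on the core of compound 1, this result fits a change that carries over from one core to the other with little effect, but it does not show that the change does so, nor that the two cores respond differently: the same change on two cores in this assay, a 1.1-fold higher number (0.02 log units; within the scatter) from compound 1 to compound 2 and an at least 1.0-fold lower number (0.03 log units; that floor lies within the scatter) from compound 3 to compound 4; the limit leaves it open whether they differ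

Still open, as far as these compounds go, are the true size of the step on the core of compound 3 and whether it matches the step on the core of compound 1. Also open, from the compounds shown here alone, is how a pyridin-2-yl or a plain phenyl group would fare on a double-bonded chain carbon bound to a double-bonded ring carbon, on either core.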